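From phenyl to pyridin-4-yl on compound 2

The source may hold more compounds than are shown below. What is called first, only, known or untested is meant among the compounds shown, and "the series" means these compounds.

Of the compounds shown here, three have been measured so far in a functional assay on RPMI-8226 cells (Homo sapiens) for inhibition, read by CCK-8 assay, with a stated time of 72 h; on this read-out higher numbers stand for weaker inhibition and lower numbers for stronger inhibition. Compound 1 (`COc1ccc(-c2oc3c(CNCC(=O)O)c(O)ccc3c(=O)c2O)c(OC)c1`) gives 66200 nM, compound 3 (`O=c1c(O)c(-c2cccc(Cl)c2Cl)oc2c(CN3CCCC3)c(O)ccc12`) gives 42800 nM, and compound 2 (`COc1ccc(-c2oc3c(CNCc4ccccc4)c(O)ccc3c(=O)c2O)c(OC)c1`) gives 14900 nM. Compound 2 therefore has the lowest number of the three and is the strongest inhibitor of this small set.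

Compound 4 (`COc1ccc(-c2oc3c(CNCc4ccncc4)c(O)ccc3c(=O)c2O)c(OC)c1`) differs from compound 2 in one place: pyridin-4-yl in place of phenyl on a saturated chain carbon bound to an amine nitrogen. Put simply, pyridin-4-yl stands in place of phenyl on a saturated chain carbon bound to an amine nitrogen.

Among the measured compounds shown here, no measured pair shows this exact swap. For the measured compounds named here, the only measured step at the same place is a 4.4-fold lower number from compound 1 to compound 2 (0.65 log units; beyond the scatter), which is modest but beyond the scatter. That step put phenyl in place of carboxy, whereas here one six-membered aromatic ring replaces another, so a smaller step seems likely. Compound 3 differs from compound 2 in more than one place and offers no clean comparison.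

The expected change is slight, a step of a 1.3-fold higher number from compound 2 to compound 4 (0.13 log units; within the scatter), towards a somewhat higher number and possibly no larger than the scatter. For compound 4 the estimated value is 20000 nM, with an expected range from 8000 nM to 50000 nM.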

Compound 4, half-maximal inhibitory concentration: 56700 nM
Compound 4: the middle estimate sits 2.8-fold (0.45 log units) below what was measured; measured number above the stated range.
By their numbers in this assay, from the lowest: compound 2; then compounds 3, 4 and 1 (each within the scatter of the next).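

In this assay this position proves sensitive to the make-up of the ring itself: replacing a ring carbon with nitrogen, while keeping a six-membered aromatic ring on the same chain carbon, gives a 3.8-fold higher number from compound 2 to compound 4 (0.58 log units; beyond the scatter) and so costs inhibition. The same comparison shows that an aromatic ring alone does not secure the lower number seen with phenyl, since the step of a 1.2-fold lower number from compound 1 to compound 4 (0.07 log units; within the scatter) leaves the pyridin-4-yl compound level with the carboxy compound. The data offered here contain nothing that explains this loss.

Going by these compounds, what remains open is whether the loss follows the ring nitrogen wherever it sits, which pyridin-2-yl and pyridin-3-yl rings on the same chain carbon could test, or belongs to pyridin-4-yl alone. It is also unclear whether phenyl is the best group here, or whether a saturated cyclohexyl ring, a phenyl ring carrying a methoxy group or a chlorine, or a longer chain such as 2-phenylethyl would bring the number lower still.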